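Bromo for Ethyl on the Aromatic Carbon of Compound 1

A few compounds are considered here, and "the series" means these few. Any claim that something is new, unique, unknown or untested is made for them only; others in the source may bear on it.

Of the compounds shown here, two sharing one core have been measured so far. Compound 1 `CCc1ccnc(C(=O)Nc2nn[nH]n2)c1` was tested in a functional assay on the whole organism for inhibition, with Rattus norvegicus as the target, at a dose of 3 mg/kg by the oral route (a higher number here means a stronger effect of the compound at the dose given, a lower number a weaker effect), and compound 1 gave 29%. Compound 2 `COc1cccc(C(=O)Nc2nn[nH]n2)n1` was tested in the same way, and compound 2 gave 36%. On these two numbers compound 1 holds the lower figure, with compound 2 its nearest neighbour, and the gap between them lies within the usual scatter of repeated measurements, so no order between compound 1 and compound 2 can be read from them.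

The next step leaves compound 1 for compound 3 `O=C(Nc1nn[nH]n1)c1cc(Br)ccn1`, which has not yet been measured. The change is bromo in place of ethyl on an aromatic carbon, on an aromatic carbon of a six-membered aromatic ring with one nitrogen. For the measured compounds named here, no measured pair shows what this exchange does in this assay, and the two numbers known so far sit close together. The account therefore expects for compound 3 a step of a number 1 percentage points higher from compound 1 to compound 3 (within the scatter), with no clear direction beyond the scatter. Compound 3 is estimated at 30%, expected to fall between 10% and 50%.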

Compound 3, a percentage reported as inhibition, in the whole organism at one dose (the size of the read-out at that dose, not a potency): 34%
Beside the measured number, compound 3's estimate is 4 percentage points below it; low and high end bracket the measured number.
By their numbers in this assay, from the lowest: compounds 1, 3 and 2 (each within the scatter of the next).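

In this assay, for the compounds shown here, bromo in place of ethyl on an aromatic carbon gives a number 5 percentage points higher from compound 1 to compound 3 (within the scatter), and this is the first measured step at this position, the carbon opposite the ring nitrogen. It shows that a single bromine atom can stand where the two carbons of ethyl stood without the effect at this oral dose moving beyond the scatter, so across these two groups the read-out gives no sign that this place matters, though one dose speaks only to the size of the effect and not to potency. Nothing at hand bears on why the exchange leaves the number where it is.

The compounds shown leave open whether a different kind of group on this same aromatic carbon, such as an amine, a carboxylic acid or a longer chain, would carry the number beyond the scatter in either direction, as only ethyl and bromo can be compared at this place. Going by these compounds alone, compound 2 differs from compound 1 and compound 3 in more than one place, so it offers no step that could settle the question.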